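Swapping Bromo for Methyl: An Expected Recovery of Inhibition

The source may report more compounds than this note shows. Statements on the series, on what has been measured and on what is new or still open speak of the compounds shown alone.

Compound 1, `O=C(CCC(=O)OCCCCCCSc1ccc([N+](=O)[O-])c2nonc12)Nc1ccccc1`, gives 700 nM in an assay on isolated protein for inhibition of glutathione S-transferase Mu 2 (Homo sapiens), with a stated time of 10 min; a lower number here means a stronger inhibitor, a higher number a weaker inhibitor.
Compound 2, `O=C(CCC(=O)OCCCCCCSc1ccc([N+](=O)[O-])c2nonc12)Nc1ccccc1Cl`, gives 330 nM in this assay.
Compound 3, `O=C(CCC(=O)OCCCCCCSc1ccc([N+](=O)[O-])c2nonc12)Nc1ccc(Br)cc1`, gives 32000 nM in this assay.

Compound 3 has the highest number of the three and is therefore the weakest inhibitor: the step of a 46-fold higher number from compound 1 to compound 3 (1.66 log units; beyond the scatter) and the step of a 97-fold higher number from compound 2 to compound 3 (1.99 log units; beyond the scatter) both lie well beyond the scatter. Compound 4, `Cc1ccc(NC(=O)CCC(=O)OCCCCCCSc2ccc([N+](=O)[O-])c3nonc23)cc1`, has not yet been measured. It differs from compound 3 by methyl in place of bromo on an aromatic carbon. Among the measured compounds shown here, no measured compound carries a methyl, so the only steps that bear on this change are those involving the bromo itself: a 46-fold higher number from compound 1 to compound 3 (1.66 log units; beyond the scatter) shows that adding the bromo cost most of the activity, while a 2.1-fold lower number from compound 1 to compound 2 (0.33 log units; beyond the scatter) shows that a halogen elsewhere on the ring was modest and in the other direction. Removing the bromo is therefore expected to recover a good part of the lost activity, though not necessarily all of it. For compound 4 the expected step is an 8.0-fold lower number from compound 3 to compound 4 (0.90 log units; beyond the scatter), giving an estimate of 4000 nM, with a likely range from 800 nM to 20000 nM.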

Compound 4, half-maximal inhibitory concentration: 390 nM
Beside the measured number, compound 4's estimate is 10-fold (1.01 log units) above it; the measured number lies below the stated range.
By their numbers in this assay, from the lowest: compounds 2, 4 and 1 (each within the scatter of the next, the first and the last beyond it); then compound 3.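

The step (an 82-fold lower number from compound 3 to compound 4 (1.91 log units; beyond the scatter)) shows that this place on the ring, para to a large group, can carry a substituent without a large loss, so the weak result of compound 3 goes with the bromo itself and not with any single heavy atom there. Methyl and hydrogen cannot be told apart at this place (a 1.8-fold lower number from compound 1 to compound 4 (0.25 log units; within the scatter)), and the 4-methylphenyl and 2-chlorophenyl compounds also stay within the scatter of each other (a 1.2-fold higher number from compound 2 to compound 4 (0.07 log units; within the scatter)). No measurement here gives a reason for the sharp difference between bromo and methyl.

Still open, going by these compounds, is whether chloro, methoxy or a longer chain such as ethyl at this place would behave like methyl or like bromo. An amine or a carboxylic acid there is equally untested among the compounds shown.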